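Three Analogues at the Assay Limit and a Fourth Awaited

The source may hold more compounds than are shown below. What is called first, only, known or untested is meant among the compounds shown, and "the series" means these compounds.

Measured so far:
- compound 1, `Cn1c(/C=C2\SC(=O)N(CC(=O)Nc3cc(C(C)(C)C)on3)C2=O)nc2ccccc21`: > 50000 nM
- compound 2, `CC1CN(C(=O)CN2C(=O)S/C(=C\c3nc4ccccc4n3C)C2=O)CC(C)O1`: > 50000 nM
- compound 3, `CC1CN(C(=O)CN2C(=O)S/C(=C\c3nc4ccccc4n3C(C)C)C2=O)CC(C)O1`: > 50000 nM

In a functional assay on PC-3 cells (Homo sapiens) for inhibition, read by MTT assay, with a stated time of 48 h (on this read-out lower numbers stand for stronger inhibition and higher numbers for weaker inhibition), compound 1 gives > 50000 nM, which is a limit of the assay and not a number. In this assay compound 2 likewise gives > 50000 nM, again a limit. In this assay compound 3 gives > 50000 nM, also a limit.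

Two changes link these compounds. The first, ((5-(tert-butyl)-1,2-oxazol-3-yl)amino in place of 2,6-dimethylmorpholin-4-yl on a carbonyl carbon), gives a step that the two limits leave unreadable from compound 2 to compound 1. The second, (isopropyl in place of methyl on an aromatic nitrogen), gives a step that the two limits leave unreadable from compound 2 to compound 3. Neither step can be sized, since both ends rest on limits.

Compound 4, `CC(C)n1c(/C=C2\SC(=O)N(CC(=O)Nc3cc(C(C)(C)C)on3)C2=O)nc2ccccc21`, has not yet been measured in this assay. It differs from compound 3 by (5-(tert-butyl)-1,2-oxazol-3-yl)amino in place of 2,6-dimethylmorpholin-4-yl on a carbonyl carbon. The place line of this change reads word for word as in the change from compound 2 to compound 1, so it is the same change, now made on the core that carries isopropyl rather than methyl on the aromatic nitrogen.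

The step from compound 3 to compound 4 is expected to be a step that the limit leaves unreadable from compound 3 to compound 4, a guess that rests only on the limit of > 50000 nM in this assay, at which 3 of the 3 values shown sit, and therefore cannot point in any direction. Compound 4 is expected to give about 60000 nM, with a range from 15000 nM to 250000 nM, most likely reported only as a limit.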

Compound 4, half-maximal inhibitory concentration: > 50000 nM
Compound 4: a limit, no number (the forecaster's own chance of this, stated with the estimate: 85%); the middle value does not contradict the limit.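

In this assay compound 4 gives > 50000 nM, a limit of the assay and not a number. Compound 1 and compound 3 also rest on limits, so the steps to compound 4 from each of them cannot be read. The compounds shown leave open whether either the (5-(tert-butyl)-1,2-oxazol-3-yl)amino group or the isopropyl group changes inhibition at all, because every result ends at the same point: the limit of > 50000 nM in this assay, at which 4 of the 4 values shown sit.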